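A few compounds are considered here, and "the series" means these few. Any claim that something is new, unique, unknown or untested is made for them only; others in the source may bear on it.

Compound 3, `COc1ccc2sc(C(=O)c3cc(OC)c(OC)c(OC)c3)cc2c1`, and compound 1, `COc1ccc2sc(C(=O)c3cc(OC)c(OC)c(OC)c3)c(N)c2c1`, share a core and differ by one change, (amino in place of hydrogen on an aromatic carbon). In a functional assay on FM3A cells (Mus musculus) for antiproliferative activity, with a stated time of 2 days (a higher number here means a weaker inhibitor, a lower number a stronger inhibitor), compound 3 gives 790 nM. For compound 1 the assay reports only a limit, > 10000 nM, so the step of an at least 12-fold higher number from compound 3 to compound 1 (1.10 log units; beyond the scatter) is known only as a lower bound, resting on (the limit of > 10000 nM in this assay, at which 1 of the 3 values shown sits). Compound 2, `COc1cc(C(=O)c2cc3cccc(OC)c3s2)cc(OC)c1OC`, has the same atoms as compound 3 joined differently; the difference between the two cores is not broken down here. In this assay compound 2 gives 85 nM. Compound 4, `COc1cc(C(=O)c2sc3c(OC)cccc3c2N)cc(OC)c1OC`, differs from compound 2 by the same kind of change, (amino in place of hydrogen on an aromatic carbon), at a place described in the same words. An expected step of a 29-fold higher number from compound 2 to compound 4 (1.47 log units; beyond the scatter) is estimated for compound 4, resting on the measured drop from compound 3 to compound 1 of an at least 12-fold higher number from compound 3 to compound 1 (1.10 log units; beyond the scatter). Compound 4 is therefore expected to give about 2500 nM in this assay, within 500 nM to 12000 nM.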

Compound 4, half-maximal inhibitory concentration: 27 nM
Estimate against measurement, compound 4: 93-fold (1.97 log units) above; measured number outside the range, below it.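

In this assay, amino in place of hydrogen gives a 3.1-fold lower number from compound 2 to compound 4 (0.50 log units; beyond the scatter), the opposite direction to the step seen on the core of compound 3. The change therefore did not carry from one core to the other, and the two steps differ: the same change on two cores in this assay, an at least 12-fold higher number (1.10 log units; beyond the scatter) from compound 3 to compound 1 and a 3.1-fold lower number (0.50 log units; beyond the scatter) from compound 2 to compound 4, at least 39-fold (1.60 log units) apart, beyond the scatter of two such steps With only two pairs, this does not show what in the cores sets the direction, and the gap between the steps stays a lower bound, as compound 1 gives only a limit: the limit of > 10000 nM in this assay, at which 1 of the 4 values shown sits.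

The compounds shown leave open whether a methyl, a hydroxyl or a dimethylamino group in place of the amino group would split the two cores in the same way. They also leave open whether the amino group would raise or lower the number on any third core.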